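From Hexyl to sec-Butyl in a Growth Assay

This account rests on a few compounds, and the source may have more. Where it says the series, first, only, none or still open, it means among the compounds named here.

In a functional assay on HBL-100 cells (Homo sapiens) for antiproliferative activity, read by sulforhodamine B assay, with a stated time of 48 h (on this read-out lower numbers stand for stronger inhibition of growth and higher numbers for weaker inhibition of growth), compound 2 `CCCCCCC(C#CC(=O)OC)O/C=C/C(=O)OC` gives 2500 nM, and compound 3 `COC(=O)C#CC(CCc1ccccc1)O/C=C/C(=O)OC` gives 2600 nM. For the measured compounds named here, these two values share the low end of the numbers measured so far. Compound 1 `CCCCCCC(C#CC(=O)O)O/C=C/C(=O)OC` gives only a limit, > 100000 nM. The largest measured change is an at least 40-fold lower number from compound 1 to compound 2 (1.60 log units; beyond the scatter), but it concerns the methyl ester, which compound 4 `CCC(C)C(C#CC(=O)OC)O/C=C/C(=O)OC` keeps. Compound 4 instead has sec-butyl in place of hexyl on a saturated chain carbon bound to an oxygen on an unsaturated carbon and a triple-bonded carbon. The closest guide is a change in the same chain, a 1.0-fold higher number from compound 2 to compound 3 (0.02 log units; within the scatter). On that evidence, no step beyond the scatter is expected in this assay, and the expected step is a 1.2-fold higher number from compound 2 to compound 4 (0.08 log units; within the scatter). For compound 4 the estimate is 3000 nM, with an expected range of 1200 nM to 8000 nM.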

Compound 4, concentration for 50% growth inhibition: 340 nM
For compound 4 the middle estimate is 8.8-fold (0.95 log units) above the measured one; the measured number lies below the stated range.
By their numbers in this assay, from the lowest: compound 4; then compounds 2 and 3 (each within the scatter of the next). At a limit, above all of these: compound 1.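

In this assay the chain on this carbon turns out to matter: sec-butyl in place of hexyl gives a 7.4-fold lower number from compound 2 to compound 4 (0.87 log units; beyond the scatter) and so opens a real gap, which the earlier change in this chain did not. The data show that this position responds to the group it carries, but only for this one pair. Nothing measured here bears on the reason for the step.

As far as these compounds go, whether branching or chain length counts remains open. A straight butyl chain or an isopropyl group on this carbon would separate the two.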